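Compound 2 to Compound 4: A Fluoro Group Exchanged

A few compounds are considered here, and "the series" means these few. Any claim that something is new, unique, unknown or untested is made for them only; others in the source may bear on it.

Values in a functional assay on HeLa cells (Homo sapiens) for cytotoxicity, read by MTT assay, with a stated time of 24 h (a higher number here means a weaker inhibitor, a lower number a stronger inhibitor), are as follows.

Compound 1 `CN1C/C(=C\c2ccc(C#N)cc2)C(=O)/C(=C/c2ccccc2F)C1` gives 1340 nM
Compound 2 `CN1C/C(=C\c2ccc(F)cc2)C(=O)/C(=C/c2ccc(C#N)cc2)C1` gives 10200 nM
Compound 3 `CN1C/C(=C\c2ccc(C#N)cc2)C(=O)/C(=C/c2ccc(Cl)cc2Cl)C1` gives 7760 nM

Compound 2 and compound 3 sit together at the high end of these three numbers, within the scatter of each other, and compound 1 lies clearly lower than both. The next compound, compound 4 `CN1C/C(=C\c2ccc(C#N)cc2)C(=O)/C(=C/c2ccc(C(F)(F)F)cc2)C1`, has not yet been measured. Its difference from compound 2 is trifluoromethyl in place of fluoro on an aromatic carbon, which is trifluoromethyl in place of fluoro on an aromatic carbon, para to a large group.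

Within the data shown here, no measured step makes this exact exchange, so the evidence is indirect. The closest guide is the replacement of 4-fluorophenyl by 2,4-dichlorophenyl, which gave a 1.3-fold lower number from compound 2 to compound 3 (0.12 log units; within the scatter). The two larger steps both start from compound 1, which carries 2-fluorophenyl. These are a 7.6-fold higher number from compound 1 to compound 2 (0.88 log units; beyond the scatter) and a 5.8-fold higher number from compound 1 to compound 3 (0.76 log units; beyond the scatter). Compound 4 keeps the 4-fluorophenyl position occupied, and it has no group from compound 1 to carry over. In this assay, no step beyond the scatter is therefore expected, and the expected result is a 1.3-fold lower number from compound 2 to compound 4 (0.11 log units; within the scatter). For compound 4 the estimated value is 8000 nM, with an expected range from 2800 nM to 23000 nM.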

Compound 4, half-maximal inhibitory concentration: 3210 nM
Beside the measured number, compound 4's estimate is 2.5-fold (0.40 log units) above it, and the stated range covers the measured number.
By their numbers in this assay, from the lowest: compound 1; then compound 4; then compounds 3 and 2 (each within the scatter of the next).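

In this assay the exchange of fluoro for trifluoromethyl on an aromatic carbon, para to a large group, gives a 3.2-fold lower number from compound 2 to compound 4 (0.50 log units; beyond the scatter) and so moves the number by more than the usual scatter. Among these compounds, the earlier compounds did not show this, since the one earlier step starting from compound 2, 2,4-dichlorophenyl in place of 4-fluorophenyl, stayed within the scatter as a 1.3-fold lower number from compound 2 to compound 3 (0.12 log units; within the scatter), so this substituent can shift the cytotoxicity reading even while the rest of the molecule stays as it is, though here the shift is only modest. The data at hand offer no measurement that would explain the shift.

From the compounds shown here alone, this single exchange gives two points at one position, so it sets no trend with the size of the group, and it remains open how a lone chloro, a methoxy group, an amine or a carboxylic acid on the same aromatic carbon would read. Going by these compounds, it is also open whether trifluoromethyl would give a similar step on the 2-fluorophenyl side of the shared core, or in cells other than those of this assay.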